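The compounds below may be only part of what the source reports. "The series", "measured", "known", "first", "only" and "open" are said of these compounds alone.

Measured in a functional assay on HepG2 cells (Homo sapiens) for inhibition, read by CCK-8 assay, with a stated time of 48 h; a lower number here means a stronger inhibitor, a higher number a weaker inhibitor:

- compound 1 `c1ccc(C2=NN(C3=NC(c4ccccc4)CS3)C(c3cccc4ccccc34)C2)cc1`: 13200 nM
- compound 2 `Cc1ccc(C2=NN(C3=NC(c4ccccc4)CS3)C(c3ccc4ccccc4c3)C2)cc1`: 14700 nM
- compound 3 `Cc1ccc(C2=NN(C3=NC(c4ccccc4)CS3)C(c3cccc4ccccc34)C2)cc1C`: 7250 nM

Compound 3 holds the lowest of the three numbers in this assay; compound 1 is nearest to it, within the scatter, while compound 2 lies beyond the scatter from it. Compound 4 `Cc1ccc(C2=NN(C3=NC(c4ccccc4)CS3)C(c3cccc4ccccc34)C2)cc1` differs from compound 3 by hydrogen in place of methyl on an aromatic carbon, in other words 3,4-dimethylphenyl to 4-methylphenyl. Among the compounds with values here, the one measured step that bears on this position is a 1.8-fold lower number from compound 1 to compound 3 (0.26 log units; within the scatter), which adds both methyls at once and stays within the scatter. Compound 4 sits structurally between compound 1 and compound 3, and its number in this assay is therefore expected to fall between those two, with no step beyond the scatter expected from compound 3. The estimated step is a 1.3-fold higher number from compound 3 to compound 4 (0.12 log units; within the scatter). For compound 4 the expected value is 9500 nM, with a range from 4500 nM to 20000 nM.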

Compound 4, half-maximal inhibitory concentration: 10400 nM
Compound 4: the middle estimate sits 1.1-fold (0.04 log units) below what was measured; measured number inside the range.
By their numbers in this assay, from the lowest: compounds 3, 4, 1 and 2 (each within the scatter of the next, the first and the last beyond it).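

In this assay, compound 4 allows each methyl to be read on its own: a 1.3-fold lower number from compound 1 to compound 4 (0.10 log units; within the scatter) and a 1.4-fold higher number from compound 3 to compound 4 (0.16 log units; within the scatter), so neither the first nor the second methyl gives a step that can be told from the scatter. The naphthalene attachment can now also be read with the rest of the structure unchanged, and a 1.4-fold lower number from compound 2 to compound 4 (0.15 log units; within the scatter) likewise stays within the scatter, so the change from naphthalen-2-yl to naphthalen-1-yl shows no clear difference here. Nothing available accounts for these small steps.

Hydrogen and methyl are the only groups compared on this aromatic carbon, so a methoxy group, a chlorine or a carboxylic acid there remains open. As far as these compounds go, whether any such group would give a step beyond the scatter from compound 4 also remains open.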